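The source may hold more compounds than are shown below. What is called first, only, known or untested is meant among the compounds shown, and "the series" means these compounds.

The series rests on a thiazole core carrying a 4,4,3-trifluorobut-3-enyl chain through an oxidised sulfur. Compound 1 `[O-][S+](CCC(F)=C(F)F)c1ncc(-c2ccncc2)s1` and compound 2 `[O-][S+](CCC(F)=C(F)F)c1nccs1` bear the sulfoxide; compound 3 `O=S(=O)(CCC(F)=C(F)F)c1ncc(-c2ccncc2)s1` and compound 4 `O=S(=O)(CCC(F)=C(F)F)c1nccs1` bear the sulfone. The difference between the two cores is not broken down here. In a functional assay on MCF7 cells (Homo sapiens) for cytotoxicity, read by MTT assay, with a stated time of 48 h (on this read-out higher numbers stand for weaker inhibition and lower numbers for stronger inhibition), compound 1 gives only a limit, > 120000 nM. In this assay compound 2 likewise gives only a limit, > 120000 nM. Compound 3 in this assay also returns only a limit, > 120000 nM. The change hydrogen in place of pyridin-4-yl on an aromatic carbon thus yields a step that the two limits leave unreadable from compound 1 to compound 2, which the limit of > 120000 nM in this assay, at which 3 of the 3 values shown sit, leaves unreadable. Compound 4 arises from compound 3 by the same kind of change, (hydrogen in place of pyridin-4-yl on an aromatic carbon), though the ring atom bearing the side group is described as carrying a large group rather than a group of 9 heavy atoms. Given (the limit of > 120000 nM in this assay, at which 3 of the 3 values shown sit), the step that the limit leaves unreadable from compound 3 to compound 4 is expected to be small, and compound 4 is estimated at 150000 nM, most likely again only a limit.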

Compound 4, half-maximal inhibitory concentration: > 120000 nM
Compound 4: a limit, no number; the forecaster's own chance of this, stated with the estimate: 85%; the middle value lies beyond the limit too.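

No step can be read from compound 3 to compound 4, because both values are only limits: the limit of > 120000 nM in this assay, at which 4 of the 4 values shown sit. The compounds shown leave open whether pyridin-4-yl or the form of the oxidised sulfur changes activity at all.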